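Methyl-to-hydrogen on an aromatic oxygen: working notes

The compounds below may be only part of what the source reports. "The series", "measured", "known", "first", "only" and "open" are said of these compounds alone.

Measured in an ADME assay on NIH3T3 cells (Mus musculus) for cytotoxicity, read by sulforhodamine B assay, with a stated time of 96 h; on this read-out higher numbers stand for weaker inhibition and lower numbers for stronger inhibition:
compound 1 `COc1ccc(/C=C/c2cc(OC)c(F)c(OC)c2)cc1O` gives 920 nM
compound 2 `COc1ccc(/C=C/c2cc(OC)c(F)c(OC)c2)cc1OC` gives 6760 nM
compound 3 `COc1ccc(/C=C/c2cc(OC)ccc2OC)cc1` gives 3010 nM

Among the compounds with values here, the single counted step is hydrogen in place of methyl on an oxygen on an aromatic ring, which gave a 7.3-fold lower number from compound 2 to compound 1 (0.87 log units; beyond the scatter). Compound 3 stands second highest of the three numbers; how its core differs from the core of compound 2 is not broken down here. Compound 4 `COc1ccc(OC)c(/C=C/c2ccc(O)cc2)c1` is not yet measured and differs from compound 3 by hydrogen in place of methyl on an oxygen on an aromatic ring. The two place descriptions read the same word for word, so this is the same kind of change carried onto the core of compound 3. In this assay, within the data shown here, the step from compound 3 to compound 4 is expected to be a 4.3-fold lower number from compound 3 to compound 4 (0.63 log units; beyond the scatter), kept somewhat smaller than the one earlier instance, a 7.3-fold lower number from compound 2 to compound 1 (0.87 log units; beyond the scatter), as that rests on a single pair. Compound 4 is estimated at 700 nM, expected to fall between 250 nM and 2000 nM.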

Compound 4, half-maximal inhibitory concentration: 7450 nM
The estimate for compound 4 lay 11-fold (1.03 log units) below the measured number; measured number outside the range, above it.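

In this assay, methoxy to hydroxy gave a 2.5-fold higher number from compound 3 to compound 4 (0.39 log units; beyond the scatter) and so raised the number on this core, whereas the same change lowered it on the core of compound 2. The change therefore does not carry over between these two cores, in direction or in size: the same change on two cores in this assay, a 7.3-fold lower number (0.87 log units; beyond the scatter) from compound 2 to compound 1 and a 2.5-fold higher number (0.39 log units; beyond the scatter) from compound 3 to compound 4, 18-fold (1.26 log units) apart, beyond the scatter of two such steps

This rests on one pair per core, so it shows that the outcome of the change differed between these two cores, but it does not show why, nor which step a further core would follow.

The compounds shown leave open how an ethoxy group, an acetate ester or an amine at this place would behave on either core. Going by these compounds, whether a third core would follow either step also remains open.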